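Methyl to Chloro Swap on Two Related Cores

The source may report more compounds than this note shows. Statements on the series, on what has been measured and on what is new or still open speak of the compounds shown alone.

Compound 1 `Cc1ccc(-c2nn(-c3cccc(Cl)c3)c(/N=C/N(C)C)c2C=O)cc1`: 7200 nM
Compound 2 `CN(C)/C=N/c1c(C=O)c(-c2ccc(Cl)cc2)nn1-c1cccc(Cl)c1`: 7400 nM
Compound 3 `Cc1ccc(-c2cc(/N=C/N(C)C)n(-c3ccc(Br)cc3)n2)cc1`: > 100000 nM (a limit of the assay, not a number)

All three were tested in a functional assay on NPC-TW01 cells (Homo sapiens) for inhibition, read by MTT assay, with a stated time of 72 h; on this read-out higher numbers stand for weaker inhibition of growth and lower numbers for stronger inhibition of growth. Compound 1 and compound 2 share one core and differ only by chloro in place of methyl on an aromatic carbon. Compound 3 carries a different core; the difference between the two cores is not broken down here. For compound 3 this assay reports only a limit, (the limit of > 100000 nM in this assay, at which 1 of the 3 values shown sits).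

Compound 4 `CN(C)/C=N/c1cc(-c2ccc(Cl)cc2)nn1-c1ccc(Br)cc1` is compound 3 after (chloro in place of methyl on an aromatic carbon), the same change as from compound 1 to compound 2, at a place described in the same words. That earlier change gave a 1.0-fold higher number from compound 1 to compound 2 (0.01 log units; within the scatter), so a step of about the same flat size is expected here, a step that the limit leaves unreadable from compound 3 to compound 4. Because compound 3 already sits at the limit of > 100000 nM in this assay, at which 1 of the 3 values shown sits, compound 4 is expected to show 150000 nM, somewhere between 40000 nM and 600000 nM, and most likely to be reported again only as a limit rather than a number.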

Compound 4, concentration for 50% growth inhibition: 60700 nM
Compound 4: middle estimate off by 2.5-fold (0.39 log units), on the high side; the range from low to high includes it.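

On the core of compound 3, the swap of 4-methylphenyl to 4-chlorophenyl in this assay gives an at least 1.6-fold lower number from compound 3 to compound 4 (0.21 log units; that floor lies within the scatter), while on the core of compound 1 the same swap gives a 1.0-fold higher number from compound 1 to compound 2 (0.01 log units; within the scatter). Set side by side, these two results show neither that the change carries over unaltered from one core to the other nor that it behaves differently on each: the same change on two cores in this assay, a 1.0-fold higher number (0.01 log units; within the scatter) from compound 1 to compound 2 and an at least 1.6-fold lower number (0.21 log units; that floor lies within the scatter) from compound 3 to compound 4; the limit leaves it open whether they differ. Going by these compounds alone, compound 3 is reported only as a limit and not as a number, so the true size of its step remains unknown, and the result shows only that compound 4 gives a measured number on a core where compound 3 does not: the limit of > 100000 nM in this assay, at which 1 of the 4 values shown sits.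

The compounds shown carry only methyl and chloro at this spot, so it remains open how a fluoro, a methoxy or an amine there would read. Also open, as far as these compounds go, is how the same swap would read on a further core where both partners give a number.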